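The compounds below may be only part of what the source reports. "The series", "measured", "known", "first", "only" and "open" are said of these compounds alone.

Measured in a functional assay on the whole organism (B cells) with Mus musculus as the target; a higher number here means a larger maximal response, a lower number a smaller maximal response:

compound 1 `C=CCn1c(=O)n(CCCCO)c2nc(N)nc(O)c21` — 12%
compound 2 `CC1OC(n2c(=O)n(C)c3c(O)nc(N)nc32)[C@H](O)[C@@H]1O` — 0%
compound 3 `C=CCn1c(=S)n(COCCO)c2nc(N)nc(O)c21` — 9%

Compound 1 holds the highest of the three numbers. Compound 3 lies within the usual scatter of it, so the two cannot be told apart. Compound 2 lies further off, beyond the scatter, and is the only one of the three whose maximal response is clearly separated from that of compound 1. All three numbers are small against the reference, and no two of the measured compounds differ in one place only, so no single change can be weighed from them.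

Compound 4 `C=CCn1c(=O)n([C@H]2CO[C@@H](CO)C2)c2nc(N)nc(O)c21` takes the step from compound 1: a group of 7 heavy atoms (5 carbon, 2 oxygen; one five-membered non-aromatic ring with 1 hetero atom) in place of a group of 5 heavy atoms (4 carbon, 1 oxygen; no ring), on an aromatic nitrogen The 4-hydroxybutyl leaves and a group with one five-membered non-aromatic ring with 1 hetero atom and 2 defined stereocentres enters on the aromatic nitrogen; the allyl group stays.

Going by the values given here, no step between measured compounds is available to guide this. The expectation rests on the low level of the whole set, where compound 1 gives 12% and nothing rises far above it. Compound 4 is expected to give about 10% in this assay, between 0% and 25%. The step of a number 2 percentage points lower from compound 1 to compound 4 (within the scatter) is expected to stay within the scatter, in no clear direction.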

Compound 4, largest response reached (reported as maximal response), in percent of the reference or control that the assay uses: 10%
Compound 4: middle estimate and measured number agree at the digits printed, and the stated range covers the measured number.
By their numbers in this assay, from the lowest: compounds 2, 3, 4 and 1 (each within the scatter of the next, the first and the last beyond it).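

Going by these compounds alone, this is the first comparison that isolates one place: in this assay, the step is a number 2 percentage points lower from compound 1 to compound 4 (within the scatter), so compound 1 and compound 4 cannot be told apart. On this aromatic nitrogen, with the allyl group kept, the open 4-hydroxybutyl chain can therefore be exchanged for a group with one five-membered non-aromatic ring with 1 hetero atom and 2 defined stereocentres, and the maximal response stays at the same low level against the reference. No separate measurement at hand bears on this result.

Still open, from the compounds shown here alone, is whether a group of another kind on this nitrogen, such as a primary amine or a carboxylic acid at the end of a longer chain, would lift the maximal response clear of that level, and whether other stereoisomers of the entering group would read the same. Also open, going by these compounds, is whether the same exchange would read alike with benzyl in place of the allyl group, since this single step comes from one background only.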